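Moving the fluorine and methyl on the aryl ketone

The source may hold more compounds than are shown below. What is called first, only, known or untested is meant among the compounds shown, and "the series" means these compounds.

In a functional assay on K562 cells (Homo sapiens) for inhibition, read by sulforhodamine B assay, with a stated time of 48 h, tested at 50 uM (on this read-out lower numbers stand for less inhibition of growth and higher numbers for more inhibition of growth at the one concentration tested), compound 1 `O=C(c1ccc(C(F)(F)F)c(F)c1)c1ccc2nc(NC(=O)C(F)(F)F)cn2c1` gives 50.1%, compound 2 `O=C(c1ccc2nc(NC(=O)C(F)(F)F)cn2c1)c1ccc(C(F)(F)F)cc1F` gives 90.2% and compound 3 `Cc1ccc(F)c(C(=O)c2ccc3nc(NC(=O)C(F)(F)F)cn3c2)c1` gives 92.6%. Compound 3 stands level with compound 2 within the scatter, and its gap to compound 1 lies beyond the scatter. Compound 4 `Cc1ccc(C(=O)c2ccc3nc(NC(=O)C(F)(F)F)cn3c2)cc1F` carries 3-fluoro-4-methylphenyl in place of 2-fluoro-5-methylphenyl on a carbonyl carbon. Within the data shown here, no measured pair differs in one place only, so the expectation is tentative. It rests on compound 1 at 50.1%, whose aryl substitution pattern compound 4 resembles more closely than compound 3 does. A drop beyond the scatter is expected, estimated as a number 24.6 percentage points lower from compound 3 to compound 4 (beyond the scatter). For compound 4 the estimated value is 68%, with an expected range of 42% to 92%.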

Compound 4, percent growth inhibition at one concentration: 52.2%
For compound 4 the middle estimate is 15.8 percentage points above the measured one, within the range that was stated.
By their numbers in this assay, from the lowest: compounds 1 and 4 (each within the scatter of the next); then compounds 2 and 3 (each within the scatter of the next).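

Same atoms, joined differently: 3-fluoro-4-methylphenyl in place of 2-fluoro-5-methylphenyl on a carbonyl carbon gives a number 40.4 percentage points lower from compound 3 to compound 4 (beyond the scatter) in this assay, so the substitution pattern alone is enough to shift this read-out. Methyl in place of trifluoromethyl on an aromatic carbon gives a number 2.1 percentage points higher from compound 1 to compound 4 (within the scatter), leaving the two compounds level. Nothing available explains either result. Open, from the compounds shown here alone, is how a methoxy, an amine or a carboxylic acid in place of that methyl would read, and whether a plain phenyl on the carbonyl carbon would read with compound 3 or compound 4.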